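Sulfamate-linked ureas and carbamates on a shared aryl core

This account rests on a few compounds, and the source may have more. Where it says the series, first, only, none or still open, it means among the compounds named here.

Compound 2 `CCC(C)N(C(=O)NS(=O)(=O)Oc1c(C(C)C)cccc1C(C)C)C(C)CC` is the reference point in an assay on liver for inhibition of sterol O-acyltransferase 1 (Rattus norvegicus), using microsomes (a higher number here means a weaker inhibitor, a lower number a stronger inhibitor), where compound 2 gives 12000 nM. Of the two numbers in hand this is the lower one; compound 1 `CCCCCCOS(=O)(=O)NC(=O)Nc1c(C(C)C)cccc1C(C)C` gives 27000 nM in this assay, and the gap between the two lies beyond the usual scatter. Compound 3 `CCOC(=O)NS(=O)(=O)Oc1c(C(C)C)cccc1C(C)C` reaches only a limit of this assay, > 50000 nM; > 50000 nM (2 entries), in two entries, so no number stands for it. Compound 4 `CC(C)c1cccc(C(C)C)c1OS(=O)(=O)NC(=O)OC1CCCCC1` has not yet been measured in this assay. Its difference from compound 2 is cyclohexyloxy in place of bis(sec-butyl)amino on a carbonyl carbon. For the measured compounds named here, no measured pair shares this change, so the size of the step is open. Compound 3 likewise bears an oxygen-linked group on the carbonyl carbon, and in this assay compound 3 gives only a limit, > 50000 nM; > 50000 nM (2 entries), which weighs toward a weaker result for compound 4. A step upward from compound 2, beyond the scatter, is expected, a 2.5-fold higher number from compound 2 to compound 4 (0.40 log units; beyond the scatter). Compound 4 is estimated at 30000 nM, within 10000 nM to 100000 nM, with a real chance that only a limit is reported.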

Compound 4, half-maximal inhibitory concentration: 38000 nM
The estimate for compound 4 lay 1.3-fold (0.10 log units) below the measured number; the measured number falls inside the stated range.
By their numbers in this assay, from the lowest: compound 2; then compounds 1 and 4 (each within the scatter of the next).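

In this assay, the exchange of bis(sec-butyl)amino for cyclohexyloxy on a carbonyl carbon gives a modest change, a 3.2-fold higher number from compound 2 to compound 4 (0.50 log units; beyond the scatter). With this oxygen-linked group in place, compound 4 still gives a number, 38000 nM. An oxygen-linked group on the carbonyl carbon therefore does not by itself bring the read-out to a limit of the assay. Compound 3, with ethoxy at the same place, gives only a limit, > 50000 nM; > 50000 nM (2 entries).

Open, as far as these compounds go, is whether cyclohexylamino on the carbonyl carbon would stay near compound 2 or near compound 4, which would separate the linking atom from the change in the group attached to it. Nothing measured in this series bears on the cause of the step.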